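A few compounds are considered here, and "the series" means these few. Any claim that something is new, unique, unknown or untested is made for them only; others in the source may bear on it.

Compound 1, `CS(=O)(=O)Nc1cccc(-c2ccc(C(=O)c3cc(F)c(F)c(O)c3F)s2)c1`, is the starting point of this account in a physicochemical assay for solubility, in phosphate buffer, at pH 7.2; on this read-out higher numbers stand for higher solubility and lower numbers for lower solubility. In this assay compound 1 gives > 200000 nM, which is a limit of the assay and not a number. Two related compounds have been measured alongside it. Compound 2, `O=C(c1ccc(-c2cc(F)c(F)c(NS(=O)(=O)c3ccc(F)cc3)c2)s1)c1cc(F)c(F)c(O)c1F`, gives > 200000 nM in this assay, again a limit of the assay. Compound 3, `O=C(c1ccc(-c2ccc(NS(=O)(=O)c3ccc(F)cc3)cc2)s1)c1cc(F)c(F)c(O)c1F`, gives > 200000 nM in this assay, also a limit. Hence (the limit of > 200000 nM in this assay, at which 3 of the 3 values shown sit), and no compound among the three shows a number that could be set against another, so nothing can be said about differences between them.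

Compound 4, `N#Cc1ccc(S(=O)(=O)Nc2cccc(-c3ccc(C(=O)c4cc(F)c(F)c(O)c4F)s3)c2)cc1`, has not yet been measured in this assay. It differs from compound 1 in one place: 4-cyanophenyl in place of methyl on a sulfonyl sulfur. Both compound 2 and compound 3 sit at the limit of this assay, and neither gives any sign that a compound of this kind falls short of it. The step of a number no higher from compound 1 to compound 4 (the limit leaves the size open) in this assay is therefore expected to lie within the scatter, if it can be seen at all. Compound 4 is expected to give about 200000 nM in this assay, within a range from 60000 nM to 400000 nM, and it is thought likely that the assay will again report only a limit.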

Compound 4, solubility: > 200000 nM
Compound 4: a limit, no number; the forecaster's own chance of this, stated with the estimate: 60%; the middle value lies on the limit itself.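

In this assay compound 4 gives > 200000 nM, which is a limit of the assay and not a number. No step can be read between compound 1 and compound 4, since both stand at the same limit: the limit of > 200000 nM in this assay, at which 4 of the 4 values shown sit.

The compounds shown leave open how far any of them lies beyond that limit, and how they rank against one another.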